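The source may hold more compounds than are shown below. What is called first, only, known or untested is meant among the compounds shown, and "the series" means these compounds.

Compound 1, `COc1ccc2nccc(C3CN(C4CCN(Cc5cc6ccccc6[nH]5)C4)C(=O)O3)c2c1`: < 50200 nM
Compound 2, `COc1ccc2nccc(C3CN(C4CCN(Cc5cc6ccccc6s5)CC4)C(=O)O3)c2c1`: 794 nM

Both compounds were tested in an in vitro functional assay on RBL cells for antagonist activity at C-C chemokine receptor type 8 (Homo sapiens), read by FLIPR and calcium flux; a higher number here means a weaker inhibitor, a lower number a stronger inhibitor. For compound 1 the entry < 50200 nM is a limit of the assay, not a number. Within the data shown here, compound 2 gives 794 nM in this assay, and this is the only number among the values shown. The other entry sits at the limit of < 50200 nM in this assay, at which 1 of the 2 values shown sits.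

Compound 3, `COc1ccc(CN2CCC(N3CC(c4ccnc5ccc(OC)cc45)OC3=O)CC2)cc1`, has not yet been measured in this assay. It differs from compound 2 in one place: 4-methoxyphenyl in place of 1-benzothiophen-2-yl on a saturated chain carbon bound to an amine nitrogen in a ring.

Among the measured compounds shown here, no step between measured compounds is available, so the size of this change cannot be read from any precedent. The step from compound 2 to compound 3 is expected to be a 3.1-fold higher number from compound 2 to compound 3 (0.50 log units; beyond the scatter), a loss of potency somewhat beyond the usual scatter, though not a large one. For compound 3 the estimate in this assay is 2500 nM, with a range from 600 nM to 10000 nM.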

Compound 3, half-maximal inhibitory concentration: 1260 nM
For compound 3 the middle estimate is 2.0-fold (0.30 log units) above the measured one; the range from low to high includes it.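

In this assay, replacing (1-benzothiophen-2-yl)methyl with 4-methoxybenzyl gives a 1.6-fold higher number from compound 2 to compound 3 (0.20 log units; within the scatter), so the two compounds cannot be told apart in this measurement. At this place, on a saturated chain carbon bound to an amine nitrogen in a ring, the 1-benzothiophen-2-yl group with its sulfur and five-membered aromatic ring can therefore be exchanged for a single six-membered aromatic ring of carbon only, and the reading stays within the scatter. No measurement shown here offers a reason for this result.

From the compounds shown here alone, the part played by the methoxy group itself remains open: a plain phenyl ring, or a phenyl ring carrying a chlorine atom or a carboxylic acid instead, could read differently. Also open, going by these compounds, is how a pyridine ring or a thiophene ring would fare at this place.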